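The source may hold more compounds than are shown below. What is called first, only, known or untested is meant among the compounds shown, and "the series" means these compounds.

Compound 1, `Cc1ccc(OCC(=O)N(Cc2cccs2)c2ccncc2)cc1`, 52 nM
Compound 2, `CCN(Cc1cncs1)C(=O)COc1ccc(C)cc1`, 1100 nM

In an assay on HEK293 cells for agonist activity at transient receptor potential cation channel subfamily M member 8 (Homo sapiens), read by fluorescence and calcium flux, with a stated time of 15 min (a lower number here means that less compound is needed, a higher number that more compound is needed for the effect), compound 1 gives 52 nM, the lowest of the two numbers shown; compound 2 gives 1100 nM, a gap that lies beyond the usual scatter. The unmeasured compound 3, `Cc1ccc(OCC(=O)N(Cc2cccs2)c2cn[nH]c2)cc1`, keeps the core of compound 1 and differs from it in one place: 1H-pyrazol-4-yl in place of pyridin-4-yl on an amide-type nitrogen. Going by the values given here, no measured pair shows this change, so the size of its effect is unknown. A moderate rise in the number is expected, a 2.9-fold higher number from compound 1 to compound 3 (0.46 log units; beyond the scatter), though a result within the scatter would not surprise. Compound 3 is therefore estimated at 150 nM, within 40 nM to 600 nM.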

Compound 3, half-maximal effective concentration: 1.4 nM
Compound 3: the middle estimate sits 110-fold (2.03 log units) above what was measured, outside the stated range (below it).
By their numbers in this assay, from the lowest: compound 3; then compound 1; then compound 2.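

In this assay, replacing pyridin-4-yl with 1H-pyrazol-4-yl on the amide-type nitrogen gives a 37-fold lower number from compound 1 to compound 3 (1.57 log units; beyond the scatter) and shows that the number depends strongly on the aromatic ring at this place. The change replaces a six-membered ring with a five-membered one and brings in a hydrogen-bond donor, and this single step cannot separate the two differences. Nothing available explains the size of the step. The compounds shown leave open whether 1-methylpyrazol-4-yl, which has a methyl group in place of the ring hydrogen on nitrogen, or phenyl at this place would keep a number close to that of compound 3.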